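A few compounds are considered here, and "the series" means these few. Any claim that something is new, unique, unknown or untested is made for them only; others in the source may bear on it.

Among the compounds with values here, in a functional assay on MCF7 cells (Homo sapiens) for cytotoxicity, read by MTT assay, with a stated time of 48 h (on this read-out lower numbers stand for stronger inhibition and higher numbers for weaker inhibition), only two compounds have numbers so far. Compound 1 `C/C(=N\NC(=S)Nc1ccccc1)c1ccccn1` gives 0.18 nM, and compound 2 `C/C(=N/NC(=S)Nc1ccccc1[N+](=O)[O-])c1ccccn1` gives 5.7 nM. This makes compound 2 the higher of the two numbers and so the weaker inhibitor, with a gap beyond the usual scatter of repeated measurements. Compound 3 `C/C(=N\NC(=S)Nc1ccccc1[N+](=O)[O-])c1ccccn1` still awaits measurement. Its difference from compound 2 is purely one of shape as drawn: the two compounds have the same atoms and bonds and differ only in configuration as drawn: 1 of 1 stereo elements differ; a double bond is drawn Z in compound 2 and E in compound 3. The two compounds have the same atoms and bonds, and a double bond is drawn Z in compound 2 and E in compound 3. Within the data shown here, no measured pair shows what such a swap does, so any forecast is uncertain. With compound 2 at 5.7 nM, a modest move toward a lower number in this assay is expected, although a step within the scatter would be no surprise. The expected change is a 2.9-fold lower number from compound 2 to compound 3 (0.45 log units; beyond the scatter). Compound 3 is estimated at 2 nM, with an expected range from 0.3 nM to 12 nM.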

Compound 3, half-maximal inhibitory concentration: 5.7 nM
Beside the measured number, compound 3's estimate is 2.9-fold (0.45 log units) below it, within the range that was stated.
By their numbers in this assay, from the lowest: compound 1; then compounds 2 and 3 (each within the scatter of the next).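

In this assay, within the data shown here, swapping the double bond drawn Z in compound 2 for the one drawn E in compound 3 gives no change at the digits printed from compound 2 to compound 3 (within the scatter), so for this nitro-bearing pair the drawn configuration leaves the read-out unmoved. Compound 3 also makes nitro in place of hydrogen on an aromatic carbon a single change, and that change gives a 32-fold higher number from compound 1 to compound 3 (1.50 log units; beyond the scatter). The large step therefore goes with the nitro group, while the double bond's drawing alone shifts nothing, and the pair that tests it is a clean comparison: the fact that compounds 2 and 3 differ only in the configuration as drawn

As far as these compounds go, whether a different group at this same place, such as an amine, a methoxy group or a chlorine atom, would cost as much remains open. Also open, from the compounds shown here alone, is whether the drawn configuration would matter equally little with hydrogen in place of nitro.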